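A few compounds are considered here, and "the series" means these few. Any claim that something is new, unique, unknown or untested is made for them only; others in the source may bear on it.

Measured compounds:
- compound 1 `C=CCn1c(=S)n(C2OC(COCc3ccccc3)[C@H]3OC(C)(C)O[C@@H]23)c2nc(N)nc(O)c21`: 47 uM
- compound 2 `CN(C)CCCn1c(=O)n(C2OC(CO)[C@@H](O)[C@H]2O)c2nc(N)nc(O)c21`: 194 uM
- compound 3 `C=CCn1c(=O)n(CCCC)c2nc(N)nc(O)c21`: 2 uM

In a functional assay (B cells) with Mus musculus as the target (on this read-out higher numbers stand for an effect only at larger amounts of compound and lower numbers for an effect already at smaller amounts), compound 2 gives 194 uM, the highest of the three numbers; compound 1 stands nearer to it and compound 3 furthest away, both gaps beyond the scatter. The unmeasured compound 4 `NC(=O)Cn1c(=O)n(C2OC(CO)[C@@H](O)[C@H]2O)c2nc(N)nc(O)c21` differs from compound 2 in one place: carbamoyl in place of 2-(dimethylamino)ethyl on a saturated chain carbon bound to an aromatic nitrogen. Among the measured compounds shown here, no step between measured compounds matches this change, so no direct precedent exists. One expects the step of a 1.1-fold higher number from compound 2 to compound 4 (0.05 log units; within the scatter) in this assay to be small, if anything toward a slightly higher number, and not clearly beyond the scatter. Compound 4 is therefore estimated at 220 uM, within a range from 60 uM to 700 uM.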

Compound 4, concentration for half-maximal effect: 190 uM
Compound 4: the middle estimate sits 1.2-fold (0.06 log units) above what was measured, within the range that was stated.
By their numbers in this assay, from the lowest: compound 3; then compound 1; then compounds 4 and 2 (each within the scatter of the next).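

In this assay, the exchange at this position, on a saturated chain carbon bound to an aromatic nitrogen, gives the first step read there (a 1.0-fold lower number from compound 2 to compound 4 (0.01 log units; within the scatter)). Carbamoyl in place of 2-(dimethylamino)ethyl thus leaves the number within the scatter, although the dimethylamino group is gone and the chain is shorter. Nothing at hand explains this result. The compounds shown leave open whether a carboxylic acid or a primary amine on this chain would read alike. They also leave open whether carbamoylmethyl would behave the same way on the core of compound 3.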